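Swapping the ring on sulfur: compound 3 to compound 4

This account rests on a few compounds, and the source may have more. Where it says the series, first, only, none or still open, it means among the compounds named here.

Measured so far:
compound 1 `Cn1c(-c2ccc(NC(=O)CSc3nc4ccccc4o3)cc2)nc(-c2ccccc2)c1-c1ccccc1`: 71.5%
compound 2 `Cn1c(-c2ccc(NC(=O)CSc3nc4cc(Cl)ccc4o3)cc2)nc(-c2ccccc2)c1-c1ccccc1`: 59.7%
compound 3 `Cn1c(-c2ccc(NC(=O)CSc3nc4ccccc4s3)cc2)nc(-c2ccccc2)c1-c1ccccc1`: 59%

All three share one core and differ only in the aromatic ring attached to the sulfur of the side chain. In a functional assay on MCF7 cells (Homo sapiens) for cytotoxicity, read by MTT assay, with a stated time of 24 h, tested at 32 ug/mL (a higher number here means a stronger effect of the compound at the concentration tested, a lower number a weaker effect), compound 1 gives 71.5%, compound 2 gives 59.7% and compound 3 gives 59%. Compound 3 sits at the low end of the three numbers: the step of a number 12.5 percentage points lower from compound 1 to compound 3 (beyond the scatter) is clear, while the step of a number 0.7 percentage points lower from compound 2 to compound 3 (within the scatter) is not, so compound 2 and compound 3 cannot be told apart.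

Compound 4 `Cc1nnc(SCC(=O)Nc2ccc(-c3nc(-c4ccccc4)c(-c4ccccc4)n3C)cc2)s1` is not yet measured. It differs from compound 3 by 5-methyl-1,3,4-thiadiazol-2-yl in place of 1,3-benzothiazol-2-yl on a sulfur. Going by the values given here, no measured step tests this particular ring. The steps that change the ring on the sulfur, a number 12.5 percentage points lower from compound 1 to compound 3 (beyond the scatter) and a number 11.8 percentage points lower from compound 1 to compound 2 (beyond the scatter), were both modest, and a number 0.7 percentage points lower from compound 2 to compound 3 (within the scatter) was within the scatter. A step of similar or smaller size is therefore expected here, a number 2 percentage points lower from compound 3 to compound 4 (within the scatter), with no direction strongly favoured. Compound 4 is estimated at 57%, between 44% and 70%.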

Compound 4, a percentage reported as activity, at one concentration (the size of the read-out at that concentration, not a potency): 83.4%
For compound 4 the middle estimate is 26.4 percentage points below the measured one; measured number outside the range, above it.
By their numbers in this assay, from the lowest: compounds 3 and 2 (each within the scatter of the next); then compound 1; then compound 4.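

In this assay, the earlier changes on this sulfur away from 1,3-benzoxazol-2-yl only lowered the number, but 5-methyl-1,3,4-thiadiazol-2-yl raises it, with a number 11.9 percentage points higher from compound 1 to compound 4 (beyond the scatter). The gain over the two lower compounds is larger, with a number 24.4 percentage points higher from compound 3 to compound 4 (beyond the scatter) and a number 23.7 percentage points higher from compound 2 to compound 4 (beyond the scatter), so the six-membered aromatic ring of carbon only, which compound 4 lacks, is not needed for a high number at this position. Nothing measured here explains why this ring gives the highest number of the four. The ring and its methyl arrive together, so the compounds shown cannot separate the contribution of the thiadiazole ring from that of the methyl. They also leave open how the number would respond if an amine, a carboxylic acid or a longer chain stood in place of that methyl.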